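The source may hold more compounds than are shown below. What is called first, only, known or untested is meant among the compounds shown, and "the series" means these compounds.

Two compounds from a shared core give the starting point. Compound 1 `C=CC(=O)Nc1ccc(-c2cc(=O)c3c(O)cc(OC)c(OC(C)C)c3o2)cc1` has a vinyl group on the carbonyl carbon that sits on the amide-type nitrogen; in a functional assay on DU-145 cells (Homo sapiens) for antiproliferative activity, read by MTT assay, with a stated time of 3 days (on this read-out lower numbers stand for stronger inhibition and higher numbers for weaker inhibition), compound 1 gives 14700 nM. Compound 2 `COc1cc(O)c2c(=O)cc(-c3ccc(NC(=O)N4CCN(C)CC4)cc3)oc2c1OC(C)C` carries a 4-methylpiperazin-1-yl group at that carbonyl carbon instead, and in this assay compound 2 gives 12500 nM. Among these two numbers compound 1 holds the higher one, but the only measured step, a 1.2-fold lower number from compound 1 to compound 2 (0.07 log units; within the scatter), is too small to separate the two compounds.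

Compound 3 `COc1cc(O)c2c(=O)cc(-c3ccc(NC(=O)N4CC(C)NC(C)C4)cc3)oc2c1OC(C)C` is the compound not yet measured. Against compound 1 it differs in a single place: 3,5-dimethylpiperazin-1-yl in place of vinyl on a carbonyl carbon. The step from compound 1 to compound 2 is the one that bears on this change, since both replace the vinyl group by a piperazine ring on the same carbonyl carbon, and it stayed within the scatter. The expectation for compound 3 is therefore a step of about a 1.2-fold lower number from compound 1 to compound 3 (0.07 log units; within the scatter) in this assay, that is, no movement beyond the scatter. On that basis compound 3 is estimated at 12500 nM in this assay, within a range from 5000 nM to 30000 nM.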

Compound 3, half-maximal inhibitory concentration: 41900 nM
Estimate against measurement, compound 3: 3.4-fold (0.53 log units) below, outside the stated range (above it).
By their numbers in this assay, from the lowest: compounds 2 and 1 (each within the scatter of the next); then compound 3.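

At this carbonyl carbon, the first pair gave no sign that a piperazine ring in place of vinyl moves the number, yet in this assay the change to 3,5-dimethylpiperazin-1-yl gives a 2.9-fold higher number from compound 1 to compound 3 (0.45 log units; beyond the scatter) and so shifts the result toward weaker inhibition. The comparison of the two piperazine rings is the more informative one, since a ring is present on both sides: 3,5-dimethylpiperazin-1-yl in place of 4-methylpiperazin-1-yl gives a 3.4-fold higher number from compound 2 to compound 3 (0.53 log units; beyond the scatter) and is also a modest step beyond the scatter. This position therefore responds to how the piperazine ring is substituted, and the presence of a ring alone does not settle the outcome.

No measurement at hand accounts for the difference between these two rings. From the compounds shown here alone, it remains open whether an unsubstituted piperazine, a morpholine ring or a simple dimethylamino group on the same carbonyl carbon would give a number close to that of compound 2 or close to that of compound 3, and so whether the two ring methyl groups or the free ring nitrogen goes with the step.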